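Shortening the alkynyl chain of compound 2

The compounds below may be only part of what the source reports. "The series", "measured", "known", "first", "only" and "open" are said of these compounds alone.

Of the compounds shown here, two have been measured in a functional assay on HEL cells (Homo sapiens) for cytotoxicity; a lower number here means that less compound is tolerated, a higher number that more compound is tolerated. Compound 1, `CCCCC#Cc1cc2cn([C@@H]3O[C@H](CO)[C@@H](O)[C@@H]3O)c(=O)nc2o1`, is recorded at > 144000 nM, which is a limit of the assay rather than a number. For the measured compounds named here, compound 2, `CCCCCCCCCCC#Cc1cc2cn([C@H]3C[C@H](O)[C@@H](CO)O3)c(=O)nc2o1`, is the only compound with an actual number in this assay, where compound 2 gives 36000 nM. The other value shown is a limit, (the limit of > 144000 nM in this assay, at which 1 of the 2 values shown sits), so compound 2 stands alone as the single measured point.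

Compound 3, `CCCCC#Cc1cc2cn([C@H]3C[C@H](O)[C@@H](CO)O3)c(=O)nc2o1`, differs from compound 2 by hydrogen in place of hexyl on a saturated chain carbon, four bonds along the chain from a triple-bonded carbon. Going by the values given here, no step between two measured compounds is available to size this change directly. Compound 3 carries the same shorter alkynyl chain as compound 1. Compound 1 stands at > 144000 nM, a limit. An upward move in this assay, beyond the usual scatter, is therefore expected for compound 3 relative to compound 2. The step from compound 2 to compound 3 is expected to be a 3.3-fold higher number from compound 2 to compound 3 (0.52 log units; beyond the scatter). Compound 3 is estimated at 120000 nM, with a range from 45000 nM to 300000 nM, and a fair chance that the assay again reports only a limit.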

Compound 3, half-maximal cytotoxic concentration: > 150000 nM
Compound 3: no number, only a limit; the forecaster's own chance of this, stated with the estimate: 50%; middle value at least 1.2-fold (0.09 log units) from the limit.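

Removing the hexyl portion at this place, on a saturated chain carbon, four bonds along the chain from a triple-bonded carbon, gives an at least 4.1-fold higher number from compound 2 to compound 3 (0.61 log units; beyond the scatter) in this assay. For the compounds shown here, this is the first step that can be sized, and it shows that, with the sugar portion held the same, the longer chain of compound 2 goes with a lower number than the shorter chain. The size remains only a lower bound, as compound 3 gives a limit and not a number: the limit of > 150000 nM in this assay, at which 1 of the 3 values shown sits.

On these data alone, the step between compound 1 and compound 3, hydrogen in place of hydroxy on a saturated ring carbon, cannot be read, as both values are limits, so the effect of that hydroxy in this assay stays open. Also open is how the number changes along the way from one chain to the other: the compounds shown include no chain of intermediate length, and none that ends in an amine or a carboxylic acid.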